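The source may hold more compounds than are shown below. What is called first, only, known or untested is meant among the compounds shown, and "the series" means these compounds.

Among the compounds with values here, compound 2 `CCCCCCCCCCCCCC(=O)C(F)(F)F` stands highest of the two numbers so far in an assay for inhibition of Fatty-acid amide hydrolase 1 (Rattus norvegicus) (on this read-out higher numbers stand for weaker inhibition and lower numbers for stronger inhibition), where compound 2 gives 2300 nM; its nearest neighbour is compound 1 `CCCCCCCCCCCCCCCCCC(=O)C(F)(F)F`, which in this assay gives 1200 nM, and the step of a 1.9-fold higher number from compound 1 to compound 2 (0.28 log units; within the scatter) lies within the scatter. Compound 3 `O=C(CCCCCCCc1ccccc1)C(F)(F)F` differs from compound 2 by phenyl in place of hexyl on a saturated chain carbon, seven bonds along the chain from a carbonyl carbon. Within the data shown here, the one measured step, a change on the saturated chain far from the carbonyl carbon, is the only guide, and it moved the number by no more than the scatter; no measured pair shows what an aromatic ring entering at that place does, so the phenyl has no direct precedent here. The expectation for compound 3 is therefore a step of a 1.2-fold lower number from compound 2 to compound 3 (0.06 log units; within the scatter), no larger than the scatter in either direction, with a wide margin. The estimate for compound 3 in this assay is 2000 nM, between 600 nM and 6500 nM.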

Compound 3, half-maximal inhibitory concentration: 120 nM
Beside the measured number, compound 3's estimate is 17-fold (1.22 log units) above it; the whole stated range lies above it.
By their numbers in this assay, from the lowest: compound 3; then compounds 1 and 2 (each within the scatter of the next).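

Phenyl in place of hexyl on a saturated chain carbon, seven bonds along the chain from a carbonyl carbon, gives a 19-fold lower number from compound 2 to compound 3 (1.28 log units; beyond the scatter) in this assay, so this position responds strongly to the group it carries. Within the data shown here, the earlier change on the chain, a 1.9-fold higher number from compound 1 to compound 2 (0.28 log units; within the scatter), stayed within the scatter, and only this exchange, in which the two groups match in heavy atoms, hydrogen-bond donors and acceptors and differ in the six-membered aromatic ring of carbon only, shows a large step. The compounds shown do not separate the contribution of the ring from that of the length of the chain carrying it. From the compounds shown here alone, how a longer chain ending in phenyl, or an amine or a carboxylic acid at this place, would compare remains open. No measurement offered here accounts for the size of this step.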